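A few compounds are considered here, and "the series" means these few. Any claim that something is new, unique, unknown or untested is made for them only; others in the source may bear on it.

Compound 3 `Cc1ccc(-c2nc3c(N4CCN(C(=O)COc5ccc(Cl)cc5)CC4)nc(N)nc3s2)cc1` gives 350 nM in a functional assay on cells (Lymphocyte, Homo sapiens) (a higher number here means a weaker inhibitor, a lower number a stronger inhibitor), the lowest of the three numbers recorded. Compound 1 `Nc1nc(N2CCN(C(=O)COc3ccc(Cl)cc3)CC2)c2nc(-c3ccc(F)cc3)sc2n1` gives 490 nM in this assay, and the step of a 1.4-fold lower number from compound 1 to compound 3 (0.15 log units; within the scatter) lies within the scatter, so these two compounds cannot be ranked against each other. Compound 2 `Nc1nc(N2CCN(C(=O)COc3ccc(Cl)cc3)CC2)c2nc(CCOc3ccc(F)cc3)sc2n1` gives 3540 nM in this assay, and the step of a 10-fold lower number from compound 2 to compound 3 (1.00 log units; beyond the scatter) lies beyond the scatter. Compound 4 `Nc1nc(N2CCN(C(=O)COc3ccc(Cl)cc3)CC2)c2nc(-c3cccnc3)sc2n1` differs from compound 3 in one place: pyridin-3-yl in place of 4-methylphenyl on an aromatic carbon. Of the measured steps, the closest in kind is a 1.4-fold lower number from compound 1 to compound 3 (0.15 log units; within the scatter), which exchanged one small group on an aromatic carbon and stayed within the scatter. The steps of a 7.2-fold higher number from compound 1 to compound 2 (0.86 log units; beyond the scatter) and a 10-fold lower number from compound 2 to compound 3 (1.00 log units; beyond the scatter) exchanged a whole aryl group for 2-(4-fluorophenoxy)ethyl and back again, a change of a different kind from the one at hand. Since compound 4 keeps a six-membered aromatic ring at this position, the expectation is a small step, a 1.7-fold higher number from compound 3 to compound 4 (0.23 log units; within the scatter), in this assay, leaning if anything toward a higher number. The estimate for compound 4 is 600 nM, with a range from 250 nM to 1500 nM.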

Compound 4, half-maximal inhibitory concentration: 50 nM
Compound 4: the middle estimate sits 12-fold (1.08 log units) above what was measured; the measured number lies below the stated range.
By their numbers in this assay, from the lowest: compound 4; then compounds 3 and 1 (each within the scatter of the next); then compound 2.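

In this assay, pyridin-3-yl in place of 4-methylphenyl gave a 7.0-fold lower number from compound 3 to compound 4 (0.85 log units; beyond the scatter), and pyridin-3-yl in place of 4-fluorophenyl gave a 9.8-fold lower number from compound 1 to compound 4 (0.99 log units; beyond the scatter), whereas exchanging those two substituted phenyl groups had given only a 1.4-fold lower number from compound 1 to compound 3 (0.15 log units; within the scatter). For the compounds shown here, this position therefore responds to a change in the six-membered aromatic ring itself, which the earlier compounds did not show, and pyridin-3-yl in place of 2-(4-fluorophenoxy)ethyl gives the largest step in the set, a 71-fold lower number from compound 2 to compound 4 (1.85 log units; beyond the scatter). No measurement at hand speaks to why the number fell.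

Pyridin-3-yl differs from the other two aryl groups both in its ring nitrogen and in lacking a methyl or fluoro substituent, so the compounds shown do not separate these two changes. A plain phenyl group would address that question, and pyridin-4-yl would test whether the place of the ring nitrogen matters.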